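A few compounds are considered here, and "the series" means these few. Any claim that something is new, unique, unknown or untested is made for them only; others in the source may bear on it.

Measured in a functional assay on HL-60 cells (Homo sapiens) for cytotoxicity, read by WST assay, with a stated time of 48 h; on this read-out higher numbers stand for an effect only at larger amounts of compound and lower numbers for an effect already at smaller amounts:
- compound 1 `O=C1OC[C@H](Cc2ccccc2)[C@H]1Cc1ccccc1`: 77000 nM
- compound 2 `COCOc1ccccc1C[C@H]1C(=O)OC[C@@H]1Cc1ccccc1`: 76000 nM
- compound 3 `CCCCOc1ccccc1C[C@H]1C(=O)OC[C@@H]1Cc1ccccc1`: 20000 nM

Of these three, compound 3 has the lowest number, 20000 nM, and its gaps to the other two lie beyond the scatter. Compound 4 `Cc1ccccc1C[C@H]1C(=O)OC[C@@H]1Cc1ccccc1` carries methyl in place of butoxy on an aromatic carbon.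

Two measured steps show what a group at this place has done. Butoxy in place of hydrogen gave a 3.9-fold lower number from compound 1 to compound 3 (0.59 log units; beyond the scatter), a modest step, whereas methoxymethoxy in place of hydrogen gave a 1.0-fold lower number from compound 1 to compound 2 (0.01 log units; within the scatter), which is within the scatter. Propyl in place of methoxy gave a 3.8-fold lower number from compound 2 to compound 3 (0.58 log units; beyond the scatter), also modest. No methyl group has been measured here, so the forecast is uncertain. Since only butoxy moved the number, losing it should undo much of that step, taking the number back toward compound 1 at 77000 nM.

The estimated change is a 2.5-fold higher number from compound 3 to compound 4 (0.40 log units; beyond the scatter), a modest rise in the number. Compound 4 is therefore expected at about 50000 nM, with an estimated range of 20000 nM to 110000 nM.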

Compound 4, half-maximal effective concentration: 57000 nM
Compound 4: middle estimate off by 1.1-fold (0.06 log units), on the low side; low and high end bracket the measured number.
By their numbers in this assay, from the lowest: compound 3; then compounds 4, 2 and 1 (each within the scatter of the next).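

In this assay, methyl on this aromatic carbon gives a 1.4-fold lower number from compound 1 to compound 4 (0.13 log units; within the scatter), and against methoxymethoxy it gives a 1.3-fold lower number from compound 2 to compound 4 (0.12 log units; within the scatter), so hydrogen, methyl and methoxymethoxy cannot be told apart here. Replacing butoxy with methyl gives a 2.9-fold higher number from compound 3 to compound 4 (0.45 log units; beyond the scatter), which leaves butoxy as the only group among these four that separates from the others, and compound 2 shows that an oxygen on the ring does not by itself bring that step. Nothing available on these compounds gives a reason why butoxy stands apart.

The compounds shown leave open whether the step depends on chain length, which ethoxy or hexyloxy at this place could test, and whether the oxygen of butoxy is needed, which a plain pentyl chain could test. They also leave open what a hydroxyl or an amine would do here.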